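Series notes: heteroaryl swap on the shared core

This account rests on a few compounds, and the source may have more. Where it says the series, first, only, none or still open, it means among the compounds named here.

Core set. In an assay on microsomes from liver for inhibition of acyl-CoA desaturase 1 (Rattus norvegicus) (a higher number here means a weaker inhibitor, a lower number a stronger inhibitor), compound 1 `FC(F)(F)c1ccccc1OC1CCN(c2ccc(-n3ccnc3)nn2)CC1` gives 4 nM. Compound 2 `CCc1ccccc1OC1CCN(c2ccc(-n3ccnc3)nn2)CC1` gives 4 nM in this assay, and compound 3 `CC(=O)c1ccccc1OC1CCN(c2ccc(-n3ccnc3)nn2)CC1` gives 34 nM. On these numbers compound 1 stands level with compound 2 at the digits shown, the two together the lowest of the three. The measured steps all sit at the aryl ether of the shared core: no change at the digits printed from compound 1 to compound 2 (within the scatter), an 8.5-fold higher number from compound 1 to compound 3 (0.93 log units; beyond the scatter) and an 8.5-fold higher number from compound 2 to compound 3 (0.93 log units; beyond the scatter).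

Change to compound 4. Compound 4 `CC(C)Cc1nnc(-c2ccc(N3CCC(Oc4ccccc4C(F)(F)F)CC3)nn2)s1` differs from compound 1 in one place: 5-isobutyl-1,3,4-thiadiazol-2-yl in place of 1H-imidazol-1-yl on an aromatic carbon. None of the three measured steps touches this part of the core; each alters only the group on the aryl ether, and the trifluoromethyl of compound 1 is kept in compound 4. Going by the values given here, the measured steps therefore give no direct precedent for the size or direction of the change from compound 1 to compound 4, and the expectation rests on compound 1 alone, with a wide range. The step is expected to be a 2.5-fold higher number from compound 1 to compound 4 (0.40 log units; beyond the scatter). Compound 4 is estimated at 10 nM in this assay, with a range from 2 nM to 60 nM.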

Compound 4, half-maximal inhibitory concentration: 37 nM
Compound 4: the middle estimate sits 3.7-fold (0.57 log units) below what was measured; measured number inside the range.
By their numbers in this assay, from the lowest: compounds 1 and 2 (each within the scatter of the next); then compounds 3 and 4 (each within the scatter of the next).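

In this assay, the position carrying 1H-imidazol-1-yl on the shared core now has its first measured step, a 9.3-fold higher number from compound 1 to compound 4 (0.97 log units; beyond the scatter), whereas every earlier step lay at the group on the aryl ether. With the trifluoromethyl held constant, the result shows that this position is not silent: replacing 1H-imidazol-1-yl with 5-isobutyl-1,3,4-thiadiazol-2-yl shifts the number beyond the scatter, although this single step alters the five-membered aromatic ring and adds the isobutyl chain together, so it cannot assign the shift to either part. No supporting measurement is available to explain the shift.

On these data alone, it remains open whether the shift follows the 1,3,4-thiadiazole ring or the isobutyl chain, and a methyl, a longer chain, an amine or a carboxylic acid in place of isobutyl on the same ring would help separate the two. As far as these compounds go, it also remains open whether the step keeps its size and direction when ethyl or acetyl replaces trifluoromethyl on the aryl ether, as in compound 2 and compound 3.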